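The source may hold more compounds than are shown below. What is called first, only, known or untested is meant among the compounds shown, and "the series" means these compounds.

In a functional assay on KYSE-450 cells (Homo sapiens) for inhibition, read by MTT assay, with a stated time of 48 h (on this read-out higher numbers stand for weaker inhibition and lower numbers for stronger inhibition), compound 1 `C/C=C/C(=O)N(Cc1ccc(OC)c([N+](=O)[O-])c1)c1cc(OC)c(OC)c(OC)c1` gives 510 nM. Compound 3 `CCCCC(=O)N(Cc1ccc(OC)c(O)c1)c1cc(OC)c(OC)c(OC)c1` gives 300 nM, within the usual scatter of the value for compound 1, while compound 2 `COc1ccc(CNc2cc(OC)c(OC)c(OC)c2)cc1[N+](=O)[O-]` gives 16800 nM. Among the compounds with values here, the one measured step, a 33-fold higher number from compound 1 to compound 2 (1.52 log units; beyond the scatter), puts hydrogen in place of (prop-1-en-1-yl)carbonyl on a nitrogen and leaves the nitro group untouched, so it bears only weakly on what follows. Compound 4 `C/C=C/C(=O)N(Cc1ccc(OC)c(N)c1)c1cc(OC)c(OC)c(OC)c1` has amino in place of nitro on an aromatic carbon, ortho to a methoxy group: amino in place of nitro on an aromatic carbon. Within the data shown here, no measured step makes this change. Compound 3 also lacks the nitro group and still gives 300 nM, so no step beyond the scatter is expected. The expected step is a 1.7-fold lower number from compound 1 to compound 4 (0.23 log units; within the scatter). For compound 4, the estimated value is 300 nM, with an expected range from 80 nM to 1100 nM.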

Compound 4, half-maximal inhibitory concentration: 310 nM
Compound 4: middle estimate off by 1.0-fold (0.01 log units), on the low side, and the stated range covers the measured number.
By their numbers in this assay, from the lowest: compounds 3, 4 and 1 (each within the scatter of the next); then compound 2.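

Putting amino in place of nitro, ortho to a methoxy group, gives a 1.6-fold lower number from compound 1 to compound 4 (0.22 log units; within the scatter) and so stays within the scatter. Within the data shown here, this is the first direct comparison at this position, and it shows that, on the core of compound 1, the nitro group is not required for a value in this range. Nothing available here explains why the two groups give such similar values. Still open, from the compounds shown here alone, is whether this position accepts other groups, such as a carboxylic acid or a longer chain. Also open, going by these compounds, is whether plain hydrogen there would give a similar value.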